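Aryl swap on the triazole series: compound 2 to 3

The compounds below may be only part of what the source reports. "The series", "measured", "known", "first", "only" and "open" are said of these compounds alone.

- compound 1 `Cc1ccccc1-n1cc(CN2C(=O)C[C@@H]3CC[C@@]2(C)C3(C)C)nn1` (350 nM)
- compound 2 `CC1(C)[C@H]2CC[C@]1(C)N(Cc1cn(-c3ccc(Cl)cc3)nn1)C(=O)C2` (410 nM)

Among the measured compounds shown here, in a functional assay on SGC-7901 cells (Homo sapiens) for inhibition, read by MTT assay, with a stated time of 24 h (a higher number here means a weaker inhibitor, a lower number a stronger inhibitor), compound 2 cannot be separated from compound 1, the only other measured compound. For the measured compounds named here, compound 3 `COc1cccc(-n2cc(CN3C(=O)C[C@@H]4CC[C@@]3(C)C4(C)C)nn2)c1` keeps the shared core and carries 3-methoxyphenyl in place of 4-chlorophenyl on an aromatic nitrogen as its only change. Going by the values given here, one measured step bears on this: a 1.2-fold higher number from compound 1 to compound 2 (0.07 log units; within the scatter) for 4-chlorophenyl in place of 2-methylphenyl at that same nitrogen. On this single step, no change beyond the scatter is expected in this assay for compound 3. The expected step is a 1.1-fold lower number from compound 2 to compound 3 (0.03 log units; within the scatter) and one step is thin support. Compound 3 is estimated at 380 nM with a range of 180 nM to 800 nM in this read-out.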

Compound 3, half-maximal inhibitory concentration: 590 nM
Estimate against measurement, compound 3: 1.6-fold (0.19 log units) below; low and high end bracket the measured number.
By their numbers in this assay, from the lowest: compounds 1, 2 and 3 (each within the scatter of the next).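

In this assay, 3-methoxyphenyl on the aromatic nitrogen, the only one of the three aryl groups with a hydrogen-bond acceptor, gives a 1.4-fold higher number from compound 2 to compound 3 (0.16 log units; within the scatter) and also a 1.7-fold higher number from compound 1 to compound 3 (0.23 log units; within the scatter) in the same read-out. Three differently substituted phenyl groups at this nitrogen therefore remain inseparable, and adding the acceptor produces no step beyond the scatter. No available evidence bears on this result. Going by these compounds, whether a phenyl carrying an amine or a carboxylic acid would move the number beyond the scatter remains open. The same applies to replacing the aryl group with a longer alkyl chain.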